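The compounds below may be only part of what the source reports. "The series", "measured", "known", "first", "only" and "open" are said of these compounds alone.

Measured compounds:
compound 1 `C[C@@H]1CCCN1c1c(C#N)c2c(N)nc(Nc3cn(C)nc3C(F)(F)F)nc2n1C` — in an ADME assay on microsomes from liver (Homo sapiens) for pharmacokinetics (on this read-out higher numbers stand for fast clearance and lower numbers for slow clearance), compound 1 gives 33.3 mL/min/kg
compound 2 `Cc1nn(CC(C)(C)O)cc1Nc1nc(N)c2c(C#N)c(N3CCC[C@H]3C)n(C)c2n1` — in this assay compound 2 gives 50 mL/min/kg

Within the data shown here, only two numbers are at hand. Among the measured compounds shown here, the number for compound 2 and the number for compound 1 sit within the usual scatter of each other, so nothing separates them beyond the noise of repeated runs, and no step between measured compounds can be drawn from them.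

Compound 3 `Cc1nn(C2COC2)cc1Nc1nc(N)c2c(C#N)c(N3CCC[C@H]3C)n(C)c2n1` has not yet been measured. It is built from compound 2 by one change: oxetan-3-yl in place of 2-hydroxy-2-methylpropyl on an aromatic nitrogen. Both groups keep one hydrogen-bond acceptor, while the hydrogen-bond donor of the group that leaves is gone.

For the measured compounds named here, with no measured pair showing what such a swap does, the expectation for compound 3 in this assay rests on compound 2 alone, and no step beyond the scatter is expected: the estimated step is a 1.3-fold lower number from compound 2 to compound 3 (0.10 log units; within the scatter). Compound 3 is therefore estimated at 40 mL/min/kg, in a range from 20 mL/min/kg to 80 mL/min/kg.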

Compound 3, clearance: 46.7 mL/min/kg
For compound 3 the middle estimate is 1.2-fold (0.07 log units) below the measured one; the measured number falls inside the stated range.
By their numbers in this assay, from the lowest: compounds 1, 3 and 2 (each within the scatter of the next).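

In this assay, placing oxetan-3-yl instead of 2-hydroxy-2-methylpropyl on the aromatic nitrogen gives a 1.1-fold lower number from compound 2 to compound 3 (0.03 log units; within the scatter) and so stays within what repeat runs would give, even though the hydrogen-bond donor of the leaving group is gone and a four-membered ring enters. Exchanging the whole group on the nitrogen of the aromatic ring, 3-methyl-1-(oxetan-3-yl)-1H-pyrazol-4-yl in place of 1-methyl-3-(trifluoromethyl)-1H-pyrazol-4-yl, gives a 1.4-fold higher number from compound 1 to compound 3 (0.15 log units; within the scatter) and also stays within that scatter. No measurement is at hand that could explain either result.

All three compounds therefore remain indistinguishable in this read-out, and these two swaps show no group that separates them. Going by these compounds, what a piperidin-4-yl ring or a carboxylic acid chain on that aromatic nitrogen would give remains open.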